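The source may hold more compounds than are shown below. What is called first, only, known or untested is meant among the compounds shown, and "the series" means these compounds.

Measured in a functional assay (mast cells) for inhibition, with Rattus norvegicus as the target; on this read-out higher numbers stand for an effect only at larger amounts of compound and lower numbers for an effect already at smaller amounts:
- compound 1 `CC1CC/C(=N\Nc2ccccc2O)c2ncc(C(=O)O)c(=O)n21`: 208000 nM
- compound 2 `CC1CC/C(=N\Nc2ccc(O)cc2)c2ncc(C(=O)O)c(=O)n21`: 1300 nM

Of these two, compound 2 has the lower number at 1300 nM, so it acts at smaller amounts than compound 1, which reads 208000 nM. The next compound, compound 3 `Cc1ccc(N/N=C2\CCC(C)n3c2ncc(C(=O)O)c3=O)cc1`, keeps the core of compound 2 but carries methyl in place of hydroxy on an aromatic carbon, para to a large group: methyl in place of hydroxy on an aromatic carbon. It has not yet been measured.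

Within the data shown here, only one measured step bears on this change, and it does so indirectly. That step, a 160-fold lower number from compound 1 to compound 2 (2.20 log units; beyond the scatter), is large and shows that the placement of the hydroxy group on the phenyl ring matters in this assay. However, no measured compound lacks the hydroxy group, so the size of the loss remains open. A moderate move to a higher number is expected, much smaller than the measured step, with a wide margin in either direction. The expected change is a 2.3-fold higher number from compound 2 to compound 3 (0.36 log units; beyond the scatter). For compound 3 the estimated value is 3000 nM, with an expected range of 400 nM to 20000 nM.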

Compound 3, half-maximal effective concentration: 280 nM
Beside the measured number, compound 3's estimate is 11-fold (1.03 log units) above it; the whole stated range lies above it.
By their numbers in this assay, from the lowest: compound 3; then compound 2; then compound 1.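

In this assay the exchange of hydroxy for methyl on an aromatic carbon, para to a large group, gives a 4.6-fold lower number from compound 2 to compound 3 (0.67 log units; beyond the scatter), so within this pair a hydrogen-bond donor and acceptor at this place are not required for an effect at smaller amounts of compound. Among these compounds, the earlier compounds showed only that moving the hydroxy group changed the number, whereas the comparison of the 4-methylphenyl and 2-hydroxyphenyl compounds now spans a 740-fold lower number from compound 1 to compound 3 (2.87 log units; beyond the scatter) and shows that a group without oxygen can stand at the end of this range with the lower number. No available evidence accounts for the lower number with methyl.

The compounds shown leave open how an ethyl group, a methoxy group or a chlorine atom would read at this same place, and whether a plain phenyl group with no added group there would keep the number of compound 3 . They also leave open whether the methyl gain carries over to a core in which the carboxylic acid is replaced by an ester or an amide.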